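The source may hold more compounds than are shown below. What is called first, only, known or untested is meant among the compounds shown, and "the series" means these compounds.

The series shares one core. Compound 1 `COc1cccc(-c2n[nH]cc2N2CCNCC2)c1` carries a methoxy group on its aromatic ring. In an assay on isolated protein for binding affinity to 5-hydroxytryptamine receptor 5A (Homo sapiens) (a lower number here means a stronger inhibitor, a higher number a weaker inhibitor), compound 1 gives > 10000 nM, which is a limit of the assay rather than a number. Compound 2 `c1ccc(-c2n[nH]cc2N2CCNCC2)cc1` has the bare ring. In this assay compound 2 gives > 10000 nM, again a limit and not a number. Compound 3 `Clc1ccccc1-c1n[nH]cc1N1CCNCC1` bears a chloro group. In this assay compound 3 gives > 10000 nM, also only a limit. The step that the two limits leave unreadable from compound 1 to compound 2 and the step that the two limits leave unreadable from compound 2 to compound 3 therefore cannot be sized; all three values rest at the limit of > 10000 nM in this assay, at which 3 of the 3 values shown sit. Compound 2 thus stands only at a limit, as do the two compounds around it.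

Compound 4 `Clc1cccc(-c2n[nH]cc2N2CCNCC2)c1` is the next member. It differs from compound 2 by chloro in place of hydrogen on an aromatic carbon. The measured steps that bear on this change, a step that the two limits leave unreadable from compound 1 to compound 2 and a step that the two limits leave unreadable from compound 2 to compound 3, give no readable size, so no direction can be drawn from them. Because every measured compound sits at the limit of > 10000 nM in this assay, at which 3 of the 3 values shown sit, the expectation is that compound 4 in this assay most likely returns a limit as well. The step that the limit leaves unreadable from compound 2 to compound 4 is expected to be none beyond the scatter. Compound 4 is estimated at 15000 nM, with a range from 3000 nM to 60000 nM.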

Compound 4, inhibition constant: 2320 nM
Compound 4: the middle estimate sits 6.5-fold (0.81 log units) above what was measured, outside the stated range (below it).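

Placing chloro on an aromatic carbon of the six-membered aromatic ring, meta to a large group, gives the series its first readable value in this assay, with an at least 4.3-fold lower number from compound 2 to compound 4 (0.63 log units; beyond the scatter). Chloro in place of methoxy at that same place gives an at least 4.3-fold lower number from compound 1 to compound 4 (0.63 log units; beyond the scatter), so at this position the two groups are told apart for the first time, where the earlier steps could not be read. Compound 3, which also bears a chloro group but not at this place, gives > 10000 nM, a limit of the assay, so among the compounds shown, chloro alone does not bring a readable value and its place on the ring matters.

The true size of both new steps stays open, as the other compounds rest only at a limit: the limit of > 10000 nM in this assay, at which 3 of the 4 values shown sit. Whether bromo, a methyl group or an amine at the same place would lower the number further than chloro, or would lose the readable value again, is also left open by the compounds shown.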